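The compounds below may be only part of what the source reports. "The series", "measured", "known", "first", "only" and "open" are said of these compounds alone.

Of the compounds shown here, two have been measured so far. Compound 1 `CCCCCCCCCCCOc1ccccc1CCC(=O)O[C@@H]1CCOC[C@H]1OP(=O)(O)OC[C@H](N)C(=O)O` and compound 2 `CCCCCCCCCCCOc1ccccc1CCC(=O)O[C@H]1COCC[C@H]1OP(=O)(O)OC[C@H](N)C(=O)O` share the same atoms apart from the way two ring carbons are drawn, and in an assay on HEK293 cells for agonist activity at putative P2Y purinoceptor 10 (Mus musculus), with a stated time of 1 h (on this read-out higher numbers stand for larger maximal responses and lower numbers for smaller maximal responses), compound 1 gives 10.6%. In this assay compound 2 gives 8.6%. This is the lower of the two numbers, but only by a gap that lies within the scatter of repeated measurements, so the two values cannot be told apart.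

Compound 3 `CCCCCCCCCCCOc1ccccc1CCC(=O)O[C@@H]1COCC[C@@H]1OP(=O)(O)OC[C@H](N)C(=O)O` is not yet measured. The change from compound 2 to compound 3 is the two compounds have the same atoms and bonds; at least one stereo element is drawn with a configuration in one of them and without one in the other: 2 of 4 stereo elements differ; a stereocentre at a saturated ring carbon is drawn S in compound 2 and R in compound 3; a stereocentre at a saturated ring carbon is drawn R in compound 2 and S in compound 3. Going by the values given here, no step between two measured compounds is available, so there is nothing here to say whether flipping these two ring stereocentres shifts the maximal response at all.

On these grounds compound 3 is expected to show a step of a number 1.4 percentage points higher from compound 2 to compound 3 (within the scatter), that is, no change beyond the scatter. The estimated maximal response for compound 3 is therefore 10%, with a range from 3% to 25%.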

Compound 3, largest response reached (Emax), in percent of the reference or control that the assay uses: 12%
Compound 3: middle estimate off by 2 percentage points, on the low side, and the stated range covers the measured number.
By their numbers in this assay, from the lowest: compounds 2, 1 and 3 (each within the scatter of the next).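

In this assay, going by these compounds alone, inverting both saturated ring stereocentres together gives a number 3.4 percentage points higher from compound 2 to compound 3 (within the scatter), and this is the first step that can be read directly. For this pair, then, the maximal response does not shift beyond the scatter when these two ring carbons take the opposite drawn configurations, so a double inversion at this position has no detectable effect here. One caution goes with this reading, as the comparison rests on how the structures are drawn: the fact that one of compounds 2 and 3 is drawn with a defined configuration and the other without, at the place where they differ

Both stereocentres change at once in this step, so the effect of inverting only one of them cannot be separated out, and a small effect of one could be offset by the other. The compounds shown also leave open whether the maximal response would respond to a change in another part of the shared core, such as a longer chain in place of the present one or a trifluoromethyl group added to it, since all of these compounds keep the same atoms and bonds.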